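Amide variation on a fluorinated naphthylamine core

The compounds below may be only part of what the source reports. "The series", "measured", "known", "first", "only" and "open" are said of these compounds alone.

Measured compounds:
- compound 1, `O=C(Nc1c(C(O)(C(F)(F)F)C(F)(F)F)ccc2ccccc12)c1ccccc1Cl`: 2040 nM
- compound 2, `Cc1cccc(C(=O)Nc2c(C(O)(C(F)(F)F)C(F)(F)F)ccc3ccccc23)c1`: 23 nM
- compound 3, `O=C(Nc1c(C(O)(C(F)(F)F)C(F)(F)F)ccc2ccccc12)c1ccco1`: 9 nM

Three compounds have been characterised in an assay on LtK cells with ATP-sensitive inward rectifier potassium channel 11 (Homo sapiens) as the target; a lower number here means that less compound is needed, a higher number that more compound is needed for the effect. Compound 1 stands at the highest number of the three; compound 2 lies nearest, an 89-fold lower number from compound 1 to compound 2 (1.95 log units; beyond the scatter), and compound 3 lies furthest, a 230-fold lower number from compound 1 to compound 3 (2.36 log units; beyond the scatter). Between the two lower compounds the gap is smaller, a 2.6-fold lower number from compound 2 to compound 3 (0.41 log units; beyond the scatter).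

The step considered here leads from compound 1 to compound 4, `O=C(Nc1c(C(O)(C(F)(F)F)C(F)(F)F)ccc2ccccc12)c1cccnc1`, which has not yet been measured in this assay . The change is pyridin-3-yl in place of 2-chlorophenyl on a carbonyl carbon.

Both measured steps that start from compound 1 replace the 2-chlorophenyl group on the carbonyl carbon, and both gave large drops in number, an 89-fold lower number from compound 1 to compound 2 (1.95 log units; beyond the scatter) and a 230-fold lower number from compound 1 to compound 3 (2.36 log units; beyond the scatter). Compound 4 keeps a six-membered aromatic ring, as compound 2 does, so a large step in the same direction is expected, a 34-fold lower number from compound 1 to compound 4 (1.53 log units; beyond the scatter). The estimate for compound 4 in this assay is 60 nM, expected between 10 nM and 400 nM.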

Compound 4, half-maximal effective concentration: 60 nM
Beside the measured number, compound 4's estimate shows no gap at the digits printed; the measured number falls inside the stated range.
By their numbers in this assay, from the lowest: compound 3; then compound 2; then compound 4; then compound 1.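

In this assay, the pyridin-3-yl group shows that a six-membered aromatic ring with a ring nitrogen and no chlorine can also stand on this carbonyl carbon with a much lower number than the 2-chlorophenyl group, giving a 34-fold lower number from compound 1 to compound 4 (1.53 log units; beyond the scatter). It does not match the other two replacements, however, with a 6.7-fold higher number from compound 3 to compound 4 (0.82 log units; beyond the scatter) and a 2.6-fold higher number from compound 2 to compound 4 (0.42 log units; beyond the scatter), so the ring carrying a hetero atom ranks behind both furan-2-yl and 3-methylphenyl. No data are available to explain these differences.

Still open, going by these compounds, is whether pyridin-2-yl or pyridin-4-yl would give a number like that of compound 4, and whether 3-chlorophenyl would stay as high as compound 1 or fall towards compound 2. The compounds shown also leave open how a non-aromatic group, such as a cyclohexyl ring or a longer alkyl chain, would behave on this carbonyl carbon.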